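Carbamate return on a five-membered ring in the piperidine carboxamide series

The source may hold more compounds than are shown below. What is called first, only, known or untested is meant among the compounds shown, and "the series" means these compounds.

Going by the values given here, compound 3 `CCN(CC)S(=O)(=O)c1ccc(S(=O)(=O)N2CCC[C@@H](C(=O)NC3CN(C(=O)NC(C)(C)C)C3)C2)cc1` gives 1400 nM in a functional assay on MIA PaCa-2 cells (Homo sapiens) for inhibition, read by MTT assay, with a stated time of 3 days (on this read-out higher numbers stand for weaker inhibition and lower numbers for stronger inhibition), the second highest of the three numbers measured so far. Compound 1 `CCN(CC)S(=O)(=O)c1ccc(S(=O)(=O)N2CCC[C@@H](C(=O)NC3CN(C(=O)OC(C)(C)C)C3)C2)cc1` gives 100 nM and compound 2 `CCN(CC)S(=O)(=O)c1ccc(S(=O)(=O)N2CCC[C@@H](C(=O)NC3CN(C(=O)C4CC4)C3)C2)cc1` gives 3100 nM, so compound 3 sits between them. The steps that separate them, a 14-fold higher number from compound 1 to compound 3 (1.15 log units; beyond the scatter) and a 2.2-fold lower number from compound 2 to compound 3 (0.35 log units; beyond the scatter), both come from changes on the carbonyl carbon attached to the four-membered ring.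

Compound 4 `CCN(CC)S(=O)(=O)c1ccc(S(=O)(=O)N2CCC[C@@H](C(=O)N[C@H]3CCN(C(=O)OC(C)(C)C)C3)C2)cc1` is not yet measured. Its difference from compound 3 is 1-(tert-butoxycarbonyl)pyrrolidin-3-yl in place of 1-((tert-butyl)carbamoyl)azetidin-3-yl on an amide-type nitrogen. Part of this change, tert-butoxy in place of (tert-butyl)amino on the carbonyl carbon, reverses the step from compound 1 to compound 3, which was large. Among the compounds with values here, the other part, a five-membered ring with 1 hetero atom in place of a four-membered one, has no measured counterpart here, so its effect is unknown. On balance a lower number is expected for compound 4, estimated as 250 nM with a range of 60 nM to 1000 nM, due to the size of a 14-fold higher number from compound 1 to compound 3 (1.15 log units; beyond the scatter), tempered for the unmeasured ring change. The expected step is a 5.6-fold lower number from compound 3 to compound 4 (0.75 log units; beyond the scatter).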

Compound 4, half-maximal inhibitory concentration: 170 nM
Beside the measured number, compound 4's estimate is 1.5-fold (0.17 log units) above it; the measured number falls inside the stated range.
By their numbers in this assay, from the lowest: compounds 1 and 4 (each within the scatter of the next); then compound 3; then compound 2.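

Holding the tert-butoxycarbonyl group constant, the ring change alone gives a 1.7-fold higher number from compound 1 to compound 4 (0.23 log units; within the scatter), so in this assay the five-membered ring of 1-(tert-butoxycarbonyl)pyrrolidin-3-yl and the four-membered ring of 1-(tert-butoxycarbonyl)azetidin-3-yl cannot be told apart at this position. The steps of an 8.2-fold lower number from compound 3 to compound 4 (0.92 log units; beyond the scatter) and an 18-fold lower number from compound 2 to compound 4 (1.26 log units; beyond the scatter) each change both the ring and the group on the carbonyl carbon, and among these four compounds the two tert-butoxy carbonyl compounds, compound 1 and compound 4, stand lower than compound 2 and compound 3. No measurement at hand offers an explanation for this pattern.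

As far as these compounds go, whether cyclopropyl or (tert-butyl)amino on the carbonyl carbon ranks the same on the five-membered ring remains open. So does the effect of a smaller methoxy or a benzyloxy group in place of tert-butoxy.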